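Ethyl to trifluoromethyl on the shared core

The source may hold more compounds than are shown below. What is called first, only, known or untested is meant among the compounds shown, and "the series" means these compounds.

Measured so far in a functional assay on aorta (Rattus norvegicus, strain Wistar) (on this read-out lower numbers stand for stronger inhibition and higher numbers for weaker inhibition), on this series
- compound 1 `CC1(C)CN(C2=CCCC2=O)c2cc(N)ccc2S1` gives 3980 nM
- compound 2 `CCc1ccc2c(c1)N(C1=CCCC1=O)CC(C)(C)S2` gives 155 nM

Compound 2 has the lower of the two numbers, and its gap to compound 1 lies beyond the scatter. Next in line is compound 3 (`CC1(C)CN(C2=CCCC2=O)c2cc(C(F)(F)F)ccc2S1`), still without a value. It keeps the shared core of compound 2 and changes one group, with trifluoromethyl in place of ethyl on an aromatic carbon. Within the data shown here, the only measured step gave a 26-fold lower number from compound 1 to compound 2 (1.41 log units; beyond the scatter) and concerns that same aromatic carbon, with ethyl in place of amino. That large step shows that this assay can respond to a change at this place. Among the measured compounds shown here, no measured compound carries trifluoromethyl, so the size of the new step is poorly constrained. Starting from compound 2 at 155 nM as the reference, a step as large as the measured one is not expected. The expected step is a 1.3-fold lower number from compound 2 to compound 3 (0.11 log units; within the scatter) and it may well stay within the scatter. The estimate for compound 3 is 120 nM with an expected range from 35 nM to 420 nM in this read-out.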

Compound 3, half-maximal inhibitory concentration: 0.0417 nM
Compound 3: middle estimate off by 2900-fold (3.46 log units), on the high side; measured number outside the range, below it.
By their numbers in this assay, from the lowest: compound 3; then compound 2; then compound 1.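

In this assay, this aromatic carbon proves far more responsive than the first pair indicated: a 3700-fold lower number from compound 2 to compound 3 (3.57 log units; beyond the scatter), which exceeds a 26-fold lower number from compound 1 to compound 2 (1.41 log units; beyond the scatter) and shows that the change from ethyl to trifluoromethyl is the larger of the two steps at this place. Across the three groups on the shared core, the numbers fall from amino through ethyl to trifluoromethyl, and the whole span is a 95000-fold lower number from compound 1 to compound 3 (4.98 log units; beyond the scatter), with no listed compound going against that order. Ethyl and trifluoromethyl match in hydrogen-bond donors, hydrogen-bond acceptors, rings and net charge, so none of these features separates the two groups, although the step between them is large.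

The compounds shown leave open whether this low number is particular to trifluoromethyl or extends to other groups on the same carbon, such as chlorine, a nitrile, a methyl or a longer pentafluoroethyl chain, and whether it would persist with trifluoromethyl on a different aromatic carbon. No measurement at hand bears on what lies behind the size of this step.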